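Aryl variation at the thiazolidine carbon: compound 4 estimate

The compounds below may be only part of what the source reports. "The series", "measured", "known", "first", "only" and "open" are said of these compounds alone.

Measured compounds in a functional assay on LNCaP cells (Prostate gland, Homo sapiens) for antiproliferative activity, read by sulforhodamine B assay; a lower number here means a stronger inhibitor, a higher number a weaker inhibitor:
compound 1 `CCCCCCCCCCCCCCCCCCNC(=O)[C@H]1CSC(c2cccnc2)N1` 3600 nM
compound 2 `CCCCCCCCCCCCCCCCCCNC(=O)[C@H]1CSC(c2ccc([N+](=O)[O-])cc2)N1` 8400 nM
compound 3 `CCCCCCCCCCCCCCCCCCNC(=O)[C@H]1CSC(c2ccc(C#N)cc2)N1` 5900 nM

All three share the same core and differ only in the aryl group on the saturated ring carbon. Compound 3 sits between the values of compound 1 and compound 2, and its distance to each lies within the scatter: a 1.6-fold higher number from compound 1 to compound 3 (0.21 log units; within the scatter) and a 1.4-fold lower number from compound 2 to compound 3 (0.15 log units; within the scatter). Going by the values given here, the only step that reaches beyond the scatter is a 2.3-fold higher number from compound 1 to compound 2 (0.37 log units; beyond the scatter), and even that is modest.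

Compound 4 `CCCCCCCCCCCCCCCCCCNC(=O)[C@H]1CSC(c2c(Cl)cccc2Cl)N1` continues the same exchange at the same position: 2,6-dichlorophenyl in place of 4-cyanophenyl on a saturated ring carbon. The three measured steps all concern the aryl group on that carbon, and none of them moved the number by more than a modest amount. On that basis a change at this position is expected to leave this assay largely unchanged, with no direction that the data support.

For compound 4 an estimated value of 6000 nM is expected, with a range from 2500 nM to 15000 nM. This estimate for compound 4 corresponds to an expected step of a 1.0-fold higher number from compound 3 to compound 4 (0.01 log units; within the scatter) and is expected to remain within the scatter.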

Compound 4, half-maximal inhibitory concentration: 13100 nM
Beside the measured number, compound 4's estimate is 2.2-fold (0.34 log units) below it, within the range that was stated.
By their numbers in this assay, from the lowest: compounds 1, 3, 2 and 4 (each within the scatter of the next, the first and the last beyond it).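

In this assay, the aryl group on this saturated ring carbon can shift the number further than the first three compounds showed: 2,6-dichlorophenyl gives a 3.6-fold higher number from compound 1 to compound 4 (0.56 log units; beyond the scatter), the largest step in the set, and a 2.2-fold higher number from compound 3 to compound 4 (0.35 log units; beyond the scatter), so the exchange for 4-cyanophenyl is not neutral, though it remains modest. Against 4-nitrophenyl the same group does not separate, with a 1.6-fold higher number from compound 2 to compound 4 (0.19 log units; within the scatter), so compound 2 and compound 4 form one group in this assay, and the clear contrasts are with compound 1 and, more narrowly, compound 3. Nothing at hand bears on why this aryl exchange shifts the number.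

Open, from the compounds shown here alone, is how a plain phenyl or a 4-chlorophenyl group on this carbon would stand against compound 3 and compound 4, which would help show whether the step follows the chlorine atoms themselves or their placement on the ring. Going by these compounds, all four compounds also carry the same long chain on the amide, so it remains open whether these aryl steps hold with a shorter alkyl chain or with a chain ending in an amine.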